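The source may report more compounds than this note shows. Statements on the series, on what has been measured and on what is new or still open speak of the compounds shown alone.

Measured in a functional assay on HCT-116 cells (Homo sapiens) for cytotoxicity, read by MTT assay, with a stated time of 72 h; a higher number here means a weaker inhibitor, a lower number a stronger inhibitor:
- compound 1 `O=S(=O)(c1ccccc1)c1nc2ccccc2nc1N1CCc2ccccc2C1`: 18700 nM
- compound 2 `Cc1ccc(S(=O)(=O)c2nc3ccccc3nc2N2CCc3ccccc3C2)cc1`: 39000 nM
- compound 3 `O=S(=O)(c1ccc(F)cc1)c1nc2ccccc2nc1N1CCc2ccccc2C1`: 16600 nM

Compound 2 gives the highest number of the three, at 39000 nM. Compound 4 `Cc1ccc(S(=O)(=O)c2nc3ccccc3nc2N2CCC(O)CC2)cc1` has 4-hydroxypiperidin-1-yl in place of 1,2,3,4-tetrahydroisoquinolin-2-yl on an aromatic carbon. Within the data shown here, no measured step touches this group. All three exchange hydrogen, methyl or fluoro on an aromatic carbon elsewhere, and they offer only a rough guide to size: a 2.1-fold higher number from compound 1 to compound 2 (0.32 log units; beyond the scatter) and a 2.3-fold lower number from compound 2 to compound 3 (0.37 log units; beyond the scatter) are modest, while a 1.1-fold lower number from compound 1 to compound 3 (0.05 log units; within the scatter) lies within the scatter. No step beyond the scatter is therefore expected in this assay, and no direction can be favoured; the estimated step is a 1.1-fold lower number from compound 2 to compound 4 (0.05 log units; within the scatter). For compound 4 the expected value is 35000 nM, with an estimated range of 12000 nM to 100000 nM.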

Compound 4, half-maximal inhibitory concentration: 5440 nM
Beside the measured number, compound 4's estimate is 6.4-fold (0.81 log units) above it; the measured number lies below the stated range.
By their numbers in this assay, from the lowest: compound 4; then compounds 3 and 1 (each within the scatter of the next); then compound 2.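

In this assay, the group next to the ring nitrogen carries more weight than the substituent changes seen so far: 4-hydroxypiperidin-1-yl in place of 1,2,3,4-tetrahydroisoquinolin-2-yl gives a 7.2-fold lower number from compound 2 to compound 4 (0.86 log units; beyond the scatter) and exceeds each step among compounds 1, 2 and 3. The exchange removes an aromatic ring and adds a hydroxyl at once, so these two changes cannot be separated here. Nothing available explains the step.

Still open, as far as these compounds go, is how a plain piperidine, a morpholine or a piperazine would compare at this position. Also open, from the compounds shown here alone, is whether the step carries over to the phenylsulfonyl and 4-fluorophenylsulfonyl compounds.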